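This account rests on a few compounds, and the source may have more. Where it says the series, first, only, none or still open, it means among the compounds named here.

Compound 1 `CCCc1nc(C)c(CC(=O)O)c(=O)n1Cc1ccc(-c2ccccc2-c2nnn[nH]2)cc1`: "not determined" (no result reported)
Compound 2 `CCCc1nc(C)c(CC(=O)N(CC)CC)c(=O)n1Cc1ccc(-c2ccccc2-c2nnn[nH]2)cc1`: "not determined" (no result reported)
Compound 3 `CCCCc1nc(C)c(CC(=O)N2CCC[C@H]2C(N)=O)c(=O)n1Cc1ccc(-c2ccccc2-c2nnn[nH]2)cc1`: 0.023 mg/kg

Among the compounds with values here, in an in vivo functional assay on the whole organism for inhibition, with Rattus norvegicus as the target (on this read-out higher numbers stand for an effect only at larger amounts of compound and lower numbers for an effect already at smaller amounts), compound 3 is the only one with a number, 0.023 mg/kg. Within the data shown here, compound 1 and compound 2 have no result, so no step between measured compounds is available for comparison.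

Compound 4 `CCCCc1nc(C)c(CCC(=O)N2CCC[C@H]2C(=O)OC)c(=O)n1Cc1ccc(-c2ccccc2-c2nnn[nH]2)cc1` has yet to be measured. Relative to compound 3, it carries ((2-(methoxycarbonyl)pyrrolidin-1-yl)carbonyl)methyl in place of (2-carbamoylpyrrolidin-1-yl)carbonyl on a saturated chain carbon bound to an aromatic carbon.

Among the measured compounds shown here, with no measured step as a guide, any expectation is uncertain. Since compound 3 already acts at the small dose of 0.023 mg/kg, a change of this size seems more likely to raise the dose needed than to lower it. A moderate rise, probably beyond the usual scatter, is expected. The estimated step is a 3.5-fold higher number from compound 3 to compound 4 (0.54 log units; beyond the scatter). For compound 4, the expected value is 0.08 mg/kg, with an estimated range of 0.02 mg/kg to 0.4 mg/kg.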

Compound 4, dose for half-maximal effect: 0.063 mg/kg
Beside the measured number, compound 4's estimate is 1.3-fold (0.10 log units) above it; low and high end bracket the measured number.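

In this assay, replacing (2-carbamoylpyrrolidin-1-yl)carbonyl with ((2-(methoxycarbonyl)pyrrolidin-1-yl)carbonyl)methyl on a saturated chain carbon bound to an aromatic carbon gives a 2.7-fold higher number from compound 3 to compound 4 (0.44 log units; beyond the scatter). This first comparison shows that the position accepts a change of this size at a modest cost: more compound is needed, yet compound 4 still acts at 0.063 mg/kg. No measurement shown here explains the shift.

The step combines two changes, an added methyl link and methoxycarbonyl in place of carbamoyl, so the compounds shown cannot assign it to either one. Also open, as far as these compounds go, is how a carboxylic acid in place of the methoxycarbonyl, or a dimethylamide in place of the carbamoyl, would read in this assay.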